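Fluoro for methyl on the sulfonyl ring of compound 3

This account rests on a few compounds, and the source may have more. Where it says the series, first, only, none or still open, it means among the compounds named here.

Among the measured compounds shown here, compound 3 `COc1ccc2ncc(S(=O)(=O)c3ccc(C)cc3)c(N3CCC(C)CC3)c2c1` stands at the top of the three numbers so far measured. In an assay on isolated protein for displacement of a labelled ligand from metabotropic glutamate receptor 5 (Homo sapiens), with a stated time of 60 min, tested at 1 uM (on this read-out higher numbers stand for more inhibition at the one concentration tested (going by the name of the read-out) and lower numbers for less inhibition), compound 3 gives 90%, level with compound 1 `Cc1ccc2ncc(S(=O)(=O)c3ccc(F)cc3)c(N3CCC(C)CC3)c2c1`, which in this assay gives 90%, and furthest from compound 2 `CC1CCN(c2c(S(=O)(=O)c3ccc(F)cc3)cnc3ccc(F)cc23)CC1`, which in this assay gives 87%, a gap that lies within the scatter. Compound 4 `COc1ccc2ncc(S(=O)(=O)c3ccc(F)cc3)c(N3CCC(C)CC3)c2c1` is not yet measured. It differs from compound 3 by the exchange (fluoro in place of methyl on an aromatic carbon), the swap sitting on an aromatic carbon of a six-membered aromatic ring of carbon only, para to a large group, so that a 4-methylphenyl becomes a 4-fluorophenyl. For the measured compounds named here, one measured step bears on this: the same exchange, fluoro in place of methyl on an aromatic carbon, on a different ring of the shared core, gave a number 3 percentage points lower from compound 1 to compound 2 (within the scatter). Going by the values given here, that step lies within the scatter, and no other step among the measured compounds is relevant. He therefore expects compound 4 to move by about a number 2 percentage points lower from compound 3 to compound 4 (within the scatter) in this assay, a change not beyond the scatter in either direction. His estimate for compound 4 in this assay is 88%, with a range from 80% to 95%.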

Compound 4, a percentage reported as inhibition, at one concentration (the size of the read-out at that concentration, not a potency): 27%
Beside the measured number, compound 4's estimate is 61 percentage points above it; measured number below the stated range.
By their numbers in this assay, from the lowest: compound 4; then compounds 2, 1 and 3 (each within the scatter of the next).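

In this assay, the exchange of 4-methylphenyl for 4-fluorophenyl, on an aromatic carbon para to a large group, is far from neutral in the presence of the methoxy group, giving a number 63 percentage points lower from compound 3 to compound 4 (beyond the scatter). The 4-fluorophenyl group does not go with a low number by itself, since compounds 1 and 2 also carry it, and the methoxy group does not either, since compound 3 carries it; only compound 4 combines the two, and with the 4-fluorophenyl group held constant, the other substituent matters too, with a number 60 percentage points lower from compound 2 to compound 4 (beyond the scatter) for methoxy in place of fluoro and a number 63 percentage points lower from compound 1 to compound 4 (beyond the scatter) for methoxy in place of methyl. The effect of this exchange therefore cannot be carried over from one core to the other:  the same change on two cores in this assay, a number 3 percentage points lower (within the scatter) from compound 1 to compound 2 and a number 63 percentage points lower (beyond the scatter) from compound 3 to compound 4, 60 percentage points apart, beyond the scatter of two such steps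

The compounds shown do not tell what lies behind this dependence on the core, and these single-concentration numbers give no potencies. They also leave open whether a chloro or a trifluoromethyl in place of the fluoro on the sulfonyl ring, or an ethoxy in place of the methoxy, would keep the low number of compound 4 or return to the level of compound 3.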